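Lengthening the side chain of compound 1

The source may hold more compounds than are shown below. What is called first, only, known or untested is meant among the compounds shown, and "the series" means these compounds.

Measured so far:
compound 1, `CCc1ccnc(C(=O)Nc2nn[nH]n2)c1`: 29%
compound 2, `O=C(Nc1nn[nH]n1)c1cccc(/C=C/c2ccccc2)n1`: 73%

In a functional assay on the whole organism for inhibition, with Rattus norvegicus as the target, at a dose of 3 mg/kg by the oral route (a lower number here means a weaker effect, a higher number a stronger effect of the compound at the dose given), compound 1 gives 29%, the lower of the two numbers. For the measured compounds named here, compound 2 gives 73% in this assay, a gap beyond the scatter, but the two compounds differ in more than one place, so nothing is recorded that isolates one change between them; the only thing the pair shows is that the shared core tolerates a much larger group at the chain position with a stronger read-out.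

Compound 3, `CCCCc1ccnc(C(=O)Nc2nn[nH]n2)c1`, has not yet been measured. It differs from compound 1 by ethyl in place of hydrogen on a saturated chain carbon, two bonds along the chain from an aromatic carbon. Going by the values given here, no measured step of this kind is available, so the expected size rests on compound 1 alone. The change keeps every donor and acceptor of compound 1 and adds only saturated chain; a small upward step in this assay is expected, possibly none beyond the scatter. For compound 3 the estimated read-out in this assay is 38%, with a range from 15% to 62%, which is expected to mean a step of a number 9 percentage points higher from compound 1 to compound 3 (within the scatter).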

Compound 3, a percentage reported as inhibition, in the whole organism at one dose (the size of the read-out at that dose, not a potency): 33%
Compound 3: the middle estimate sits 5 percentage points above what was measured; the range from low to high includes it.
By their numbers in this assay, from the lowest: compounds 1 and 3 (each within the scatter of the next); then compound 2.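

In this assay, for the compounds shown here, the change from ethyl to butyl on the shared core gives a number 4 percentage points higher from compound 1 to compound 3 (within the scatter) and is the first step that isolates one place. With ethyl in place of hydrogen on a saturated chain carbon, two bonds along the chain from an aromatic carbon, the read-out at this dose cannot be told apart from that of compound 1, so this position accepts the added saturated chain with neither a measurable loss nor a measurable gain. No evidence is available on what lies behind this result.

As far as these compounds go, whether a longer chain such as hexyl, or a butyl chain ending in an amine or a carboxylic acid, would shift the read-out at this position remains open. From the compounds shown here alone, a read-out at one dose gives the size of the effect and not a potency, so how compound 1 and compound 3 would compare across a range of doses also remains open.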